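The source may hold more compounds than are shown below. What is called first, only, known or untested is meant among the compounds shown, and "the series" means these compounds.

Measured compounds:
compound 1 `N#Cc1c(N)cccc1Sc1cccc(Cl)c1`: 53000 nM
compound 2 `N#Cc1c(N)cccc1Sc1cc(Cl)cc(Cl)c1`: 3000 nM
compound 3 `N#Cc1c(N)cccc1S(=O)(=O)c1cccc(Cl)c1`: > 200000 nM

In a functional assay on MT4 cells (Homo sapiens) for cytotoxicity (a lower number here means a stronger inhibitor, a higher number a weaker inhibitor), compound 1 gives 53000 nM and compound 2 gives 3000 nM. The change between them is chloro in place of hydrogen on an aromatic carbon and it produced an 18-fold lower number from compound 1 to compound 2 (1.25 log units; beyond the scatter). For compound 3 this assay reports only a limit, > 200000 nM, which is the limit of > 200000 nM in this assay, at which 1 of the 3 values shown sits. How the core of compound 3 differs from the core of compound 1 is not broken down here.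

Compound 4 `N#Cc1c(N)cccc1S(=O)(=O)c1cc(Cl)cc(Cl)c1` is not yet measured in this assay. It differs from compound 3 by chloro in place of hydrogen on an aromatic carbon, the same change, at the same place, as that from compound 1 to compound 2. The step from compound 3 to compound 4 is expected to be an at least 3.3-fold lower number from compound 3 to compound 4 (0.52 log units; beyond the scatter), resting on compound 1 and compound 2 showing an 18-fold lower number from compound 1 to compound 2 (1.25 log units; beyond the scatter), though compound 3 itself gives only a limit. Compound 4 is estimated at 60000 nM in this assay, with a range from 15000 nM to 250000 nM and a fair chance that only a limit is reported again.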

Compound 4, half-maximal inhibitory concentration: > 200000 nM
Compound 4: only a limit was reported (the forecaster's own chance of this, stated with the estimate: 40%); middle value at least 3.3-fold (0.52 log units) away from the limit.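

In this assay, compound 3 and compound 4 are both reported only as limits, so no step between them can be read: the limit of > 200000 nM in this assay, at which 2 of the 4 values shown sit.

As far as these compounds go, whether the added chloro lowers the number in the core of compound 3, as it does from compound 1 to compound 2, stays open.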